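Side-chain amide to acid in a nucleoside sulfonate series

This account rests on a few compounds, and the source may have more. Where it says the series, first, only, none or still open, it means among the compounds named here.

Measured so far in a functional assay on CCRF-CEM cells (Homo sapiens); on this read-out lower numbers stand for higher toxicity in this test and higher numbers for lower toxicity in this test:
compound 1, `COC(=O)C(=O)CNC1=CS(=O)(=O)O[C@@]12[C@@H](CO[Si](C)(C)C(C)(C)C)O[C@@H](n1cc(C)c(=O)n(C)c1=O)[C@@H]2O[Si](C)(C)C(C)(C)C` — 5570 nM
compound 2, `CCOC(=O)CNC(=O)NC1=CS(=O)(=O)O[C@@]12[C@@H](CO[Si](C)(C)C(C)(C)C)O[C@@H](n1cc(C)c(=O)n(C)c1=O)[C@@H]2O[Si](C)(C)C(C)(C)C` — 5020 nM
compound 3, `Cc1cn([C@@H]2O[C@H](CO[Si](C)(C)C(C)(C)C)[C@@]3(OS(=O)(=O)C=C3NCC(=O)C(N)=O)[C@H]2O[Si](C)(C)C(C)(C)C)c(=O)n(C)c1=O` — 9960 nM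

Compound 3 gives the highest of the three numbers in this assay, but its steps to the others are small: a 1.8-fold higher number from compound 1 to compound 3 (0.25 log units; within the scatter) and a 2.0-fold higher number from compound 2 to compound 3 (0.30 log units; within the scatter), both within the scatter. The third measured step, a 1.1-fold lower number from compound 1 to compound 2 (0.05 log units; within the scatter), is likewise within the scatter. Among the compounds with values here, all three numbers therefore sit in one band and no compound can be set apart from the others.

Compound 4, `Cc1cn([C@@H]2O[C@H](CO[Si](C)(C)C(C)(C)C)[C@@]3(OS(=O)(=O)C=C3NCC(=O)C(=O)O)[C@H]2O[Si](C)(C)C(C)(C)C)c(=O)n(C)c1=O`, is not yet measured. Its difference from compound 3 is hydroxy in place of amino on a carbonyl carbon. Within the data shown here, the closest analogue among the measured steps is the one from compound 1 to compound 3, also a change at the same carbonyl carbon of the side chain, and that step stayed within the scatter. The other two steps, which alter the side chain more deeply, also stayed within the scatter. Nothing in the series points to a step beyond the scatter for a change of this kind.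

For compound 4 the expected step is a 1.0-fold higher number from compound 3 to compound 4 (0.00 log units; within the scatter), that is, no movement beyond the scatter. Compound 4 is thus estimated at 10000 nM in this assay, with a range from 4000 nM to 25000 nM.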

Compound 4, half-maximal cytotoxic concentration: 72600 nM
Beside the measured number, compound 4's estimate is 7.3-fold (0.86 log units) below it, and the stated range ends below it.
By their numbers in this assay, from the lowest: compounds 2, 1 and 3 (each within the scatter of the next); then compound 4.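

In this assay the carbonyl carbon of the side chain turns out to be a place where the choice of group can matter: hydroxy in place of amino gives a 7.3-fold higher number from compound 3 to compound 4 (0.86 log units; beyond the scatter), whereas amino in place of methoxy on that same carbon stayed within the scatter. Loss of the ester methyl gives a 13-fold higher number from compound 1 to compound 4 (1.12 log units; beyond the scatter), and (carboxycarbonyl)methyl in place of ((ethoxycarbonyl)methyl)carbamoyl on the amine nitrogen gives a 14-fold higher number from compound 2 to compound 4 (1.16 log units; beyond the scatter), so the carboxy compound stands apart from the single band of the other three, on the side of lower toxicity in this test. No measurement at hand accounts for this separation.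

Still open, as far as these compounds go, is whether the higher number is specific to the carboxy group or would also appear with a tetrazole or a sulfonic acid in its place. Equally open, from the compounds shown here alone, is whether it would persist with a longer chain carrying the carboxy group on the amine nitrogen, or with free hydroxy groups in place of the silyl ethers on the shared core.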